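The source may report more compounds than this note shows. Statements on the series, on what has been measured and on what is new or still open speak of the compounds shown alone.

Measured compounds in an ADME assay on RD cells (Homo sapiens) for cytotoxicity, read by MTT assay, with a stated time of 3 days; a higher number here means that more compound is tolerated, a lower number that less compound is tolerated:
- compound 1, `CCC[C@H](CCn1cncn1)c1ccccc1`: 63.1 ug/mL
- compound 2, `CCCC[C@H](CCn1cncn1)c1ccccc1`: 48.3 ug/mL

Of the compounds shown here, two have been measured so far, and they sit close together. Compound 1 gives 63.1 ug/mL in this assay, while compound 2 gives 48.3 ug/mL, a difference that comes to a 1.3-fold lower number from compound 1 to compound 2 (0.12 log units; within the scatter). Within the data shown here, compound 2 therefore stands within the scatter of its only neighbour, and nothing in these two numbers separates it from compound 1.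

Compound 3, `c1ccc(C[C@H](CCn2cncn2)c2ccccc2)cc1`, has not yet been measured. It differs from compound 2 by phenyl in place of propyl on a saturated chain carbon, two bonds along the chain from an aromatic carbon. Among the measured compounds shown here, the one measured step, from compound 1 to compound 2, exchanged hydrogen for methyl on the same chain and stayed within the scatter, so it bears only loosely on a propyl-to-phenyl exchange. The account expects compound 3 to tolerate somewhat less compound, with an expected step of a 1.5-fold lower number from compound 2 to compound 3 (0.18 log units; within the scatter). The estimate for compound 3 is 32 ug/mL, expected to lie between 15 ug/mL and 70 ug/mL.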

Compound 3, half-maximal cytotoxic concentration: 55.4 ug/mL
For compound 3 the middle estimate is 1.7-fold (0.24 log units) below the measured one; measured number inside the range.
By their numbers in this assay, from the lowest: compounds 2, 3 and 1 (each within the scatter of the next).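

In this assay, phenyl in place of propyl on a saturated chain carbon, two bonds along the chain from an aromatic carbon, gives a 1.1-fold higher number from compound 2 to compound 3 (0.06 log units; within the scatter), and phenyl in place of ethyl at that carbon gives a 1.1-fold lower number from compound 1 to compound 3 (0.06 log units; within the scatter). This place therefore takes an aromatic ring of six heavy atoms, where the chains held no ring, and the number stays within the scatter, something the earlier methyl for hydrogen step on the chain did not show. Nothing at hand speaks to why these numbers sit together.

As far as these compounds go, whether any group at this place can move the number beyond the scatter stays open. An amine, a carboxylic acid or a longer chain there would test this, as none of these groups is among the compounds shown.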